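The source may hold more compounds than are shown below. What is called first, only, known or untested is meant among the compounds shown, and "the series" means these compounds.

Working notes on the series, values in a physicochemical assay for lipophilicity, using the shake flask method, at pH 7.4; a higher number here means a more lipophilic compound, a lower number a more polar compound:

- compound 1 `CC(=O)N1CCN([C@H]2CC[C@H](Nc3ncnn4ccc([C@H]5CC[C@H](C(N)=O)CC5)c34)CC2)CC1` gives 1.4
- compound 2 `CN(C)[C@H]1CC[C@H](Nc2ncnc3[nH]ccc23)CC1` gives -0.6
- compound 3 `Cc1ccn2ncnc(N[C@H]3CC[C@H](N(C)C)CC3)c12` gives 0.2

Compound 3 stands second highest of these three numbers, above compound 2 and under compound 1, with each gap beyond the scatter. The next compound to be read is compound 4 `CN(C)[C@H]1CC[C@H](Nc2ncnn3ccc(C4CCOCC4)c23)CC1`, which differs from compound 3 in one place: oxan-4-yl in place of methyl on an aromatic carbon, two ring bonds from the ring nitrogen (oxan-4-yl in place of methyl on an aromatic carbon).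

Among the compounds with values here, no pair of measured compounds differs in a single place, so the series offers no direct measure of this change. The nearest guide is compound 1, which also carries a six-membered non-aromatic ring on that aromatic carbon and gives 1.4 in this assay, but it differs from compound 3 elsewhere as well, so it can only be a loose reference. An upward move of moderate size is therefore expected, beyond the scatter but not by a wide margin. The expected size is the estimated step of a number 0.60 log units higher from compound 3 to compound 4 (beyond the scatter) in this assay for now. In this assay compound 4 is estimated at 0.8 (expected range 0.3 to 1.3).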

Compound 4, distribution coefficient: 0.5
Beside the measured number, compound 4's estimate is 0.30 log units above it, within the range that was stated.
By their numbers in this assay, from the lowest: compound 2; then compounds 3 and 4 (each within the scatter of the next); then compound 1.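

Oxan-4-yl in place of methyl on an aromatic carbon of the five-membered aromatic ring, two ring bonds from the ring nitrogen, provides the first comparison in the series that differs in a single place, and in this assay it reads as a number 0.30 log units higher from compound 3 to compound 4 (within the scatter). The entering group brings 6 heavy atoms against 1 heavy atom, a six-membered non-aromatic ring and 1 hydrogen-bond acceptor, yet this read-out does not separate compound 3 from compound 4. No measurement is available here that would account for this result.

Within the data shown here, the pair also gives only one reading at this position, so it does not show whether the result depends on the ring oxygen or extends to other groups on the same aromatic carbon. Cyclohexyl, which has a ring with no oxygen, and piperidin-4-yl, a cyclic amine, remain open at this position, as does a longer chain such as n-butyl, each with the dimethylamino group of compound 3 and compound 4 kept in place.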